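This account rests on a few compounds, and the source may have more. Where it says the series, first, only, none or still open, it means among the compounds named here.

Measured compounds:
compound 1 `N#Cc1ccc(/C=N/Nc2nc(N)c3ncn([C@@H]4O[C@H](CO)[C@@H](O)[C@H]4O)c3n2)cc1` 4.1 nM
compound 2 `Nc1nc(N/N=C/c2ccc[nH]2)nc2c1ncn2[C@@H]1O[C@H](CO)[C@@H](O)[C@H]1O` 8 nM
compound 3 `Nc1nc(N/N=C/c2cncs2)nc2c1ncn2[C@@H]1O[C@H](CO)[C@@H](O)[C@H]1O` 22 nM

The three compounds share one core and differ only in the group on the carbon with a double bond to nitrogen. In an assay on CHO-K1 cells for displacement of a labelled ligand from adenosine receptor A1 (Homo sapiens), read by scintillation counting, with a stated time of 60 min (a lower number here means a stronger inhibitor, a higher number a weaker inhibitor), compound 1 gives the lowest of the three numbers, though its gap to compound 2 is a 2.0-fold higher number from compound 1 to compound 2 (0.29 log units; within the scatter) and so not a difference one can rely on. Its gap to compound 3 is a 5.4-fold higher number from compound 1 to compound 3 (0.73 log units; beyond the scatter), and the remaining step is a 2.8-fold higher number from compound 2 to compound 3 (0.44 log units; beyond the scatter).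

The step now followed leads from compound 1 to compound 4 `Nc1nc(N/N=C/c2ccc(Cl)c(C(F)(F)F)c2)nc2c1ncn2[C@@H]1O[C@H](CO)[C@@H](O)[C@H]1O`, which has not been measured in this assay. The change is 4-chloro-3-(trifluoromethyl)phenyl in place of 4-cyanophenyl on a carbon with a double bond to nitrogen.

The measured steps that bear on this all begin at compound 1 and replace the 4-cyanophenyl with a different ring: to compound 2 a 2.0-fold higher number from compound 1 to compound 2 (0.29 log units; within the scatter), to compound 3 a 5.4-fold higher number from compound 1 to compound 3 (0.73 log units; beyond the scatter). Both leave the number higher, one within and one beyond the scatter. Going by these compounds, compound 4 keeps a six-membered aromatic ring of carbon only, which neither of those steps did, so the swap of substituents on that ring is untested here. The account therefore expects a small step, a 2.0-fold higher number from compound 1 to compound 4 (0.29 log units; within the scatter), likely within or just beyond the scatter, in the direction of a higher number. The expected value for compound 4 is 8 nM, with a range from 2.5 nM to 25 nM.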

Compound 4, inhibition constant: > 10000 nM
Compound 4 ended at the assay's limit; the forecaster's own chance of this, stated with the estimate: 2%; middle value at least 1200-fold (3.09 log units) from the limit.
By their numbers in this assay, from the lowest: compounds 1 and 2 (each within the scatter of the next); then compound 3. At a limit, above all of these: compound 4.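

In this assay, compound 4 stands at a limit of the assay and not at a number: the limit of > 10000 nM in this assay, at which 1 of the 4 values shown sits. The earlier steps shown here exchanged one ring for another and moved the number only modestly or within the scatter, whereas this change keeps a six-membered aromatic ring of carbon only and alters what that ring carries, giving an at least 2400-fold higher number from compound 1 to compound 4 (3.38 log units; beyond the scatter), along with an at least 1200-fold higher number from compound 2 to compound 4 (3.09 log units; beyond the scatter) and an at least 450-fold higher number from compound 3 to compound 4 (2.65 log units; beyond the scatter). On the carbon with a double bond to nitrogen, then, a ring of this kind does not by itself secure a low number, and in this series the groups on that ring can count for far more than the swaps to 1H-pyrrol-2-yl or 1,3-thiazol-5-yl.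

The change removes the nitrile and brings in a chlorine and a trifluoromethyl group together, so the compounds shown cannot say whether one of these alone accounts for the step or only the pair does. Plain phenyl, 4-chlorophenyl and 3-(trifluoromethyl)phenyl would each separate these parts, and none of them is among the compounds shown.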